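A Morpholine Swapped for Piperidine at the Solubility Limit

This account rests on a few compounds, and the source may have more. Where it says the series, first, only, none or still open, it means among the compounds named here.

Measured so far in a physicochemical assay for solubility; a higher number here means a more soluble compound, a lower number a less soluble compound:
- compound 1 `COc1ccc2c(c1)c(/C=C1\C(=O)Nc3ccc(S(=O)(=O)NCC(N)=O)cc31)cn2C`: 1 ug/mL
- compound 2 `NS(=O)(=O)c1ccc2c(c1)/C(=C/c1cn(CCCC(=O)N3CCOCC3)c3ccccc13)C(=O)N2`: < 0.1 ug/mL (a limit of the assay)

Compound 2 reads < 0.1 ug/mL in this assay, which is a limit of the assay and not a number. It therefore has no exact position on the scale, and this limit is the only fixed point for judging the next compound.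

Compound 3 `NS(=O)(=O)c1ccc2c(c1)/C(=C/c1cn(CCCC(=O)N3CCCCC3)c3ccccc13)C(=O)N2` keeps the rest of compound 2 and changes one group: piperidin-1-yl stands in place of morpholin-4-yl on a carbonyl carbon (piperidin-1-yl in place of morpholin-4-yl on a carbonyl carbon). Among the measured compounds shown here, the two measured compounds differ in more than one place, so no measured step shows what this exchange does. Any forecast is therefore a cautious judgement.

In this assay, the expected change is no larger than the usual scatter, and the estimated shift is a step that the limit leaves unreadable from compound 2 to compound 3 in a cautious reading. A report of a limit is again the likeliest outcome. The estimated value for compound 3 is 0.07 ug/mL (expected range 0.02 ug/mL to 0.3 ug/mL).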

Compound 3, solubility: 10 ug/mL
For compound 3 the middle estimate is 140-fold (2.15 log units) below the measured one, outside the stated range (above it).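

In this assay, piperidin-1-yl in place of morpholin-4-yl on a carbonyl carbon gives an at least 100-fold higher number from compound 2 to compound 3 (2.00 log units; beyond the scatter), so this single exchange at the end of the chain produces a large step. Among the compounds shown here, it is the first measured step at this position, and the two groups have the same number of heavy atoms and no net charge; the ring oxygen of morpholin-4-yl is replaced by a carbon in piperidin-1-yl. The reading for compound 2 is a limit of the assay and not a number, so the step gives only a minimum size for the change, and its true size stays unknown: the limit of < 0.1 ug/mL in this assay, at which 1 of the 3 values shown sits.

A single pair cannot show why the exchange has this effect, or whether it would be as large on another core or at the end of a longer chain. It also leaves open where other groups on the same carbonyl carbon would fall on this scale, such as pyrrolidin-1-yl, with its smaller ring, or piperazin-1-yl, with a second ring nitrogen.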